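A few compounds are considered here, and "the series" means these few. Any claim that something is new, unique, unknown or untested is made for them only; others in the source may bear on it.

Working notes on the series. The shared core is the thioureido-isoxazole amide seen in compound 1 `COc1cc(Cl)nc(NC(=S)NC(=O)c2c(-c3ccc(Cl)cc3Cl)noc2C)n1`, compound 2 `Cc1cc(Cl)nc(NC(=S)NC(=O)c2c(-c3ccc(Cl)cc3Cl)noc2C)n1` and compound 3 `CSc1cc(C)nc2n/c(=N/C(=O)c3c(-c4ccc(Cl)cc4Cl)noc3C)sn12`. In a functional assay on the whole organism for inhibition, with Chenopodium ficifolium as the target, with a stated time of 72 h, tested at 10 mg/L (on this read-out higher numbers stand for more inhibition of growth at the one concentration tested and lower numbers for less inhibition of growth), compound 2 gives 28.9%, compound 1 gives 21.9% and compound 3 gives 21.9%, and all three lie within the usual scatter of one another, so no ordering among them can be read from these numbers.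

The next compound is compound 4 `COc1cc(C)nc(NC(=S)NC(=O)c2c(-c3ccc(Cl)cc3Cl)noc2C)n1`. From compound 2 it differs by methoxy in place of chloro on an aromatic carbon, next to the ring nitrogen, meta to a methyl group and opposite the ring nitrogen, so that the 4-chloro-6-methylpyrimidin-2-yl group becomes a 4-methoxy-6-methylpyrimidin-2-yl group.

Among the compounds with values here, no measured step exchanges chloro for methoxy. Within the data shown here, the one measured step on this ring, a number 7 percentage points higher from compound 1 to compound 2 (within the scatter), swaps methoxy and methyl and stays within the scatter, and the two groups are not distinguished by the data. On that basis the step to compound 4 is expected to stay within the scatter as well, with no direction to call.

Compound 4 is therefore estimated at 25% in this assay, within 12% to 38%, an expected step of a number 3.9 percentage points lower from compound 2 to compound 4 (within the scatter).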

Compound 4, percent growth inhibition at one concentration: 15.3%
Compound 4: the middle estimate sits 9.7 percentage points above what was measured, within the range that was stated.
By their numbers in this assay, from the lowest: compounds 4, 1, 3 and 2 (each within the scatter of the next, the first and the last beyond it).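

In this assay, within the data shown here, there is a step on this ring beyond the scatter for the first time: a number 13.6 percentage points lower from compound 2 to compound 4 (beyond the scatter). It is a modest step, but it shows that on the 4-chloro-6-methylpyrimidin-2-yl group, methoxy in place of chloro is not a neutral exchange at the one concentration tested, which the methoxy-to-methyl step between compound 1 and compound 2 could not show. The chloro of compound 1 can be exchanged for methyl with a smaller outcome, a number 6.6 percentage points lower from compound 1 to compound 4 (within the scatter), so among these compounds the loss of chloro does not by itself give a step beyond the scatter. Nothing measured here bears on the reason for this difference.

Three groups on two ring places cannot separate the effect of the methoxy that enters from that of the chloro that leaves. Whether bromo, an amino group or ethoxy in this place would stay with compound 2 at 28.9% or fall with compound 4 remains open, as does how any of these compounds behaves at other concentrations.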